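The source may hold more compounds than are shown below. What is called first, only, known or untested is meant among the compounds shown, and "the series" means these compounds.

Measured compounds in a functional assay on the whole organism (aorta) with Rattus norvegicus as the target; on this read-out lower numbers stand for smaller maximal responses and higher numbers for larger maximal responses:
- compound 1 `O=C1C(Nc2cccc(F)c2)=CC(=O)c2ncccc21` gives 85%
- compound 2 `O=C1C(Nc2cc(F)cc(F)c2)=CC(=O)c2ncccc21` gives 91%
- compound 3 `O=C1C=C(Nc2cccc(F)c2)C(=O)c2cnccc21` gives 89%

Compound 1 and compound 2 share one core; compound 3 is built on a core of the same atoms joined differently, and the difference between the two cores is not broken down here. Among the compounds with values here, the one change that is measured is fluoro in place of hydrogen on an aromatic carbon, which made a number 6 percentage points higher from compound 1 to compound 2 (within the scatter). Compound 3 stands within the scatter of both compound 1 and compound 2 in this assay, so no order among the three is claimed.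

Compound 4 `O=C1C=C(Nc2ccc(F)c(F)c2)C(=O)c2cnccc21` is not yet measured. It differs from compound 3 by fluoro in place of hydrogen on an aromatic carbon. This is the same kind of change as from compound 1 to compound 2, but the surroundings of the place differ: in compound 2 the entering fluoro is meta to a fluoro group and meta to a large group, in compound 4 it is ortho to a fluoro group and para to a large group. Within the data shown here, because the only measured example of this kind of change, a number 6 percentage points higher from compound 1 to compound 2 (within the scatter), stayed within the scatter, the step from compound 3 to compound 4 is expected to be small as well, a number 3 percentage points higher from compound 3 to compound 4 (within the scatter). Compound 4 is therefore estimated at 92% in this assay, with a range from 78% to 104%.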

Compound 4, largest response reached (Emax), in percent of the reference or control that the assay uses: 81%
The estimate for compound 4 lay 11 percentage points above the measured number; measured number inside the range.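

In this assay, fluoro in place of hydrogen on an aromatic carbon now gives a number 8 percentage points lower from compound 3 to compound 4 (within the scatter), and the two steps for this change do not separate: the same change on two cores in this assay, a number 6 percentage points higher (within the scatter) from compound 1 to compound 2 and a number 8 percentage points lower (within the scatter) from compound 3 to compound 4, 14 percentage points apart, within the scatter of two such steps. Neither step leaves the scatter, so the data give no sign that the core alters the result of this change, and a small step remains the working expectation on either core in this series. This does not show that the change carries over unaltered, since each core contributes a single step, the surroundings of the place differ between the two, and steps this small could hide a real difference.

The only group that enters in the compounds shown is fluoro, so it stays open whether a larger or different group on the same ring, such as a methoxy, a nitrile, an amine or a carboxylic acid, would move the read-out beyond the scatter. As far as these compounds go, it also stays open whether any such change would give the same step on both cores in this assay.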